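A ring closed within the side chain of compound 1

The source may hold more compounds than are shown below. What is called first, only, known or untested is meant among the compounds shown, and "the series" means these compounds.

Compound 1 `CCCCCCCS(=O)(=O)/C=C/c1ccc(O)c(O)c1` gives the lowest of the three numbers in a functional assay, read by fluorescence and spectrophotometry, with a stated time of 1 h (on this read-out higher numbers stand for an effect only at larger amounts of compound and lower numbers for an effect already at smaller amounts), with 7100 nM, though both other compounds lie within the scatter of it. Compound 3 `O=S(=O)(/C=C/c1ccc(O)c(O)c1)CC1CCCCC1` gives 7500 nM and compound 2 `O=S(=O)(/C=C/c1ccc(O)c(O)c1)CCCc1ccccc1` gives 11500 nM. The step of a 1.1-fold higher number from compound 1 to compound 3 (0.02 log units; within the scatter) and the step of a 1.6-fold higher number from compound 1 to compound 2 (0.21 log units; within the scatter) both stay within the scatter. Compound 4 `O=S(=O)(/C=C/c1ccc(O)c(O)c1)CCC1CCCC1` differs from compound 1 by cyclopentyl in place of pentyl on a saturated chain carbon, two bonds along the chain from a sulfonyl sulfur. The closest comparison is the step from compound 1 to compound 3, where a ring also entered in place of an open chain, and the step to compound 2 likewise brought in a ring; neither moved the number beyond the scatter. Compound 4 is therefore expected to give 7500 nM, within a range of 3500 nM to 16000 nM. The estimated step of a 1.1-fold higher number from compound 1 to compound 4 (0.02 log units; within the scatter) would stay within the scatter.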

Compound 4, half-maximal effective concentration: 6800 nM
Compound 4: middle estimate off by 1.1-fold (0.04 log units), on the high side; the range from low to high includes it.
By their numbers in this assay, from the lowest: compounds 4, 1, 3 and 2 (each within the scatter of the next).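

Closing a five-membered ring at this place, on a saturated chain carbon two bonds along the chain from a sulfonyl sulfur, stays within the scatter (a 1.0-fold lower number from compound 1 to compound 4 (0.02 log units; within the scatter)). Within the data shown here, compound 4 also stays within the scatter of both other ring-bearing compounds (a 1.1-fold lower number from compound 3 to compound 4 (0.04 log units; within the scatter); a 1.7-fold lower number from compound 2 to compound 4 (0.23 log units; within the scatter)), so the cyclopentyl ring joins the cyclohexyl and phenyl rings in giving no separable step. No evidence is at hand that bears on this result. Still open, on these data alone, is whether an amine or a carboxylic acid on this side chain would move the number beyond the scatter.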